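This account rests on a few compounds, and the source may have more. Where it says the series, first, only, none or still open, it means among the compounds named here.

Measured compounds:
Compound 1 `CN(C)/C=N/c1c(C=O)c(-c2ccc(Cl)cc2)nn1-c1cccc(Cl)c1` gives 7700 nM
Compound 2 `CN(C)/C=N/c1c(C=O)c(-c2ccc(Cl)cc2)nn1-c1ccc(Br)cc1` gives 38900 nM
Compound 3 `Cc1ccc(-c2cc(/N=C/N(C)C)n(-c3cccc(Cl)c3)n2)cc1` gives > 100000 nM

All three were tested in a functional assay on Jurkat cells (Homo sapiens) for inhibition, read by MTT assay, with a stated time of 72 h; a higher number here means a weaker inhibitor of growth, a lower number a stronger inhibitor of growth. Compound 1 and compound 2 share one core; compound 3 has another, and the difference between the two cores is not broken down here. Compound 2 differs from compound 1 by 4-bromophenyl in place of 3-chlorophenyl on an aromatic nitrogen. That change produced a 5.1-fold higher number from compound 1 to compound 2 (0.70 log units; beyond the scatter). For compound 3 the number given is only a limit of this assay, (the limit of > 100000 nM in this assay, at which 1 of the 3 values shown sits).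

Compound 4 `Cc1ccc(-c2cc(/N=C/N(C)C)n(-c3ccc(Br)cc3)n2)cc1` is not yet measured. It differs from compound 3 by 4-bromophenyl in place of 3-chlorophenyl on an aromatic nitrogen. The surroundings are not identical: in compound 1 the place is two ring bonds from the ring atom that bears a 4-chlorophenyl group and two ring bonds from the ring atom that bears a formyl group, whereas in compound 3 it is two ring bonds from the ring atom that bears a 4-methylphenyl group, so this is the same kind of change rather than the same change.

The step from compound 3 to compound 4 is expected to be a step that the limit leaves unreadable from compound 3 to compound 4, resting on the earlier step of a 5.1-fold higher number from compound 1 to compound 2 (0.70 log units; beyond the scatter) and on compound 3 already sitting at the limit > 100000 nM. Compound 4 is therefore estimated at 250000 nM, between 90000 nM and 700000 nM, and most likely to be reported as a limit again.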

Compound 4, concentration for 50% growth inhibition: > 100000 nM
Compound 4: a limit, no number; the forecaster's own chance of this, stated with the estimate: 85%; the middle value does not contradict the limit.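

Compound 3 and compound 4 both give a limit of the assay rather than a number, so no step between them can be read: the limit of > 100000 nM in this assay, at which 2 of the 4 values shown sit.

The compounds shown leave open whether 4-bromophenyl in place of 3-chlorophenyl changes growth inhibition on the core of compound 3 as it does on the core of compound 1.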